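From Phenoxyethyl to Methoxyphenyl Ethenyl on a Carbonyl Carbon

A few compounds are considered here, and "the series" means these few. Any claim that something is new, unique, unknown or untested is made for them only; others in the source may bear on it.

In an ADME assay on HepG2 2.2.15 cells (Homo sapiens) for cytotoxicity (on this read-out lower numbers stand for higher toxicity in this test and higher numbers for lower toxicity in this test), compound 1 (`O=C(CCC1CCCCC1)OCCc1c(-c2ccccc2Cl)c2cc(Cl)ccc2[nH]c1=O`) gives 160000 nM and compound 2 (`O=C(CCOc1ccccc1)OCCc1c(-c2ccccc2Cl)c2cc(Cl)ccc2[nH]c1=O`) gives 46000 nM, the lower of the two numbers. Compound 3 (`COc1cccc(/C=C/C(=O)OCCc2c(-c3ccccc3Cl)c3cc(Cl)ccc3[nH]c2=O)c1`) carries a new group: 2-(3-methoxyphenyl)ethenyl in place of 2-phenoxyethyl on a carbonyl carbon. Both the leaving and the entering group hold one six-membered aromatic ring of carbon only. Among the measured compounds shown here, the sole measured step, a 3.5-fold lower number from compound 1 to compound 2 (0.54 log units; beyond the scatter), exchanged other groups, so it offers only a modest scale and no direction for this change. The expected step is a 1.0-fold lower number from compound 2 to compound 3 (0.01 log units; within the scatter), with none anticipated beyond the scatter. The estimated value for compound 3 is 45000 nM, within an expected range of 16000 nM to 130000 nM.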

Compound 3, half-maximal cytotoxic concentration: > 1300000 nM
Compound 3: a limit, no number; the forecaster's own chance of this, stated with the estimate: 10%; middle value at least 28-fold (1.46 log units) from the limit.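

In this assay, the group on the carbonyl carbon matters far more than the shared single aromatic ring of carbon suggested: 2-(3-methoxyphenyl)ethenyl in place of 2-phenoxyethyl gives an at least 28-fold higher number from compound 2 to compound 3 (1.45 log units; beyond the scatter). In place of 2-cyclohexylethyl, the same group gives an at least 8.1-fold higher number from compound 1 to compound 3 (0.90 log units; beyond the scatter), so compound 3 reads toward lower toxicity in this test than either earlier compound. The reading of compound 3 is a limit of the assay and not a number: the limit of > 1300000 nM in this assay, at which 1 of the 3 values shown sits.

On these data alone, the full size of both steps therefore stays open. Also open, as far as these compounds go, is whether 2-(3-methoxyphenyl)ethyl, without the double bond, or 2-phenylethenyl, without the methoxy group, would read like compound 3 or like compound 2.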